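Replacing Hydroxy With a Basic Side Chain

This account rests on a few compounds, and the source may have more. Where it says the series, first, only, none or still open, it means among the compounds named here.

Compound 1, `CCCc1nc(C)c2cnnc(O)n12`: 56800 nM
Compound 2, `Cc1ncn2c(O)nncc12`: > 48000 nM
Compound 3, `CCCc1nc(C)c2c(-c3ccccc3)nnc(O)n12`: > 48000 nM

Going by the values given here, in a functional assay for inhibition, with Homo sapiens as the target (a lower number here means a stronger inhibitor, a higher number a weaker inhibitor), compound 1 gives 56800 nM, the only number among the three measured compounds. For compound 2 the value > 48000 nM is a limit of the assay and not a number. For compound 3 the value > 48000 nM is likewise a limit. The step that the limit leaves unreadable from compound 1 to compound 2 and the step that the limit leaves unreadable from compound 1 to compound 3 therefore cannot be sized, since the limit of > 48000 nM in this assay, at which 2 of the 3 values shown sit, is where two of the three values sit. All that can be said is that every measured compound is a weak inhibitor.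

Compound 4, `CCCc1nc(C)c2cnnc(NCCN(C)C)n12`, is not yet measured. It differs from compound 1 by (2-(dimethylamino)ethyl)amino in place of hydroxy on an aromatic carbon. Among the compounds with values here, neither measured step changes this group or this position, so no measured step bears directly on it, and the two unreadable steps give no direction. The step from compound 1 in this assay is estimated as a 1.9-fold lower number from compound 1 to compound 4 (0.28 log units; within the scatter), with wide uncertainty in either direction. Compound 4 is expected to give 30000 nM in this assay, with an estimated range from 5000 nM to 150000 nM.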

Compound 4, half-maximal inhibitory concentration: > 48000 nM
Compound 4 was reported as a limit; the forecaster's own chance of this, stated with the estimate: 40%; middle value at least 1.6-fold (0.20 log units) away from the limit.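

In this assay compound 4 gives > 48000 nM, which is a limit of the assay and not a number. The step from compound 1 to compound 4 therefore cannot be read: the limit of > 48000 nM in this assay, at which 3 of the 4 values shown sit. The compounds shown leave open whether any change to the core of compound 1 gives a stronger inhibitor than compound 1.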